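A few compounds are considered here, and "the series" means these few. Any claim that something is new, unique, unknown or untested is made for them only; others in the source may bear on it.

Measured compounds:
compound 1, `O=C(Nc1cccc(Cl)c1)Nc1cccc(CNc2nccnc2Cl)c1`, 6810 nM
compound 2, `O=C(Nc1cccc(CNc2nccnc2Cl)c1)Nc1ccc(F)c(Cl)c1`, 4990 nM
compound 3, `Cc1ccc(NC(=O)Nc2cccc(CNc3nccnc3Cl)c2)c(C)c1`, 9230 nM

All three were tested in a functional assay on T-24 cells (Homo sapiens) for antiproliferative activity, read by MTT assay, with a stated time of 48 h; a lower number here means a stronger inhibitor, a higher number a weaker inhibitor. Compound 1 sits between the other two numbers, and all three lie within the usual scatter of one another: the nearer is a 1.4-fold higher number from compound 1 to compound 3 (0.13 log units; within the scatter), the further is a 1.4-fold lower number from compound 1 to compound 2 (0.14 log units; within the scatter). Compound 4, `O=C(Nc1cccc(CNc2nccnc2Cl)c1)Nc1ccccc1Cl`, has not yet been measured. It differs from compound 1 only on the aryl group carried by the urea nitrogen: 2-chlorophenyl in place of 3-chlorophenyl on an amide-type nitrogen.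

Two measured steps also exchange the aryl group on that nitrogen. One is a 1.4-fold higher number from compound 1 to compound 3 (0.13 log units; within the scatter); the other is a 1.8-fold higher number from compound 2 to compound 3 (0.27 log units; within the scatter). Both stay within the scatter, so the data give no sign that this position moves the number much. A similar step is therefore expected for compound 4: a 1.0-fold higher number from compound 1 to compound 4 (0.01 log units; within the scatter), which is no more than the scatter allows. Compound 4 is expected to give about 7000 nM, with a range from 3000 nM to 16000 nM.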

Compound 4, half-maximal inhibitory concentration: 6680 nM
Beside the measured number, compound 4's estimate is 1.0-fold (0.02 log units) above it; low and high end bracket the measured number.
By their numbers in this assay, from the lowest: compounds 2, 4, 1 and 3 (each within the scatter of the next).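

In this assay, the exchange on the amide-type nitrogen keeps the same atoms and alters only the chlorophenyl isomer, 2-chlorophenyl in place of 3-chlorophenyl, and the step is a 1.0-fold lower number from compound 1 to compound 4 (0.01 log units; within the scatter) and so gives this position its closest comparison yet. The two further exchanges at this nitrogen read a 1.4-fold lower number from compound 3 to compound 4 (0.14 log units; within the scatter) and a 1.3-fold higher number from compound 2 to compound 4 (0.13 log units; within the scatter) and show that 2-chlorophenyl also stays level with the 2,4-dimethylphenyl and 3-chloro-4-fluorophenyl groups. No measurement at hand accounts for how closely these numbers lie.

From the compounds shown here alone, all four compounds carry a substituted phenyl group on this nitrogen, so it remains open whether a carboxylic acid or a dimethylamino group on that ring, or a longer chain in its place, would move the number beyond the scatter. Going by these compounds, the shared core is the same throughout, so what a change there would do also remains open.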